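Two Limits and a New Acyl Group

The source may hold more compounds than are shown below. What is called first, only, known or untested is meant among the compounds shown, and "the series" means these compounds.

Compound 1 `Cc1cccc(NNC(=O)c2ccc(NS(=O)(=O)c3cnc(O)nc3O)cc2)c1`: > 20000 nM
Compound 2 `O=C(NNc1ccc(F)cc1)c1cccc(NS(=O)(=O)c2cnc(O)nc2O)c1`: > 20000 nM

In a functional assay on OVCAR-3 cells (Homo sapiens) for antiproliferative activity, read by MTT assay, with a stated time of 24 h (a higher number here means a weaker inhibitor, a lower number a stronger inhibitor), compound 2 gives > 20000 nM, which is a limit and not a number. Compound 1 gives > 20000 nM, also only a limit. Going by the values given here, both compounds therefore stand at the limit of > 20000 nM in this assay, at which 2 of the 2 values shown sit, and no measured pair shows the effect of a single change.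

Compound 3 `O=C(NNC(=O)c1ccccc1F)c1cccc(NS(=O)(=O)c2cnc(O)nc2O)c1` carries (2-fluorophenyl)carbonyl in place of 4-fluorophenyl on an amine nitrogen.

With compound 2 at > 20000 nM, no step beyond the scatter is expected in this assay. The expected step is a step that the limit leaves unreadable from compound 2 to compound 3. Compound 3 is estimated at 25000 nM, with an expected range of 10000 nM to 60000 nM.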

Compound 3, half-maximal inhibitory concentration: 10800 nM
Compound 3: middle estimate off by 2.3-fold (0.36 log units), on the high side; the measured number falls inside the stated range.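

Going by these compounds alone, compound 3 is the first compound here with a measured number in this assay and not a limit. The value of compound 2, > 20000 nM, is a limit. Placing (2-fluorophenyl)carbonyl in place of 4-fluorophenyl on this amine nitrogen gives an at least 1.8-fold lower number from compound 2 to compound 3 (0.26 log units; that floor lies within the scatter), so a real step may be larger, but the part that can be read is no more than the floor printed.

The change adds a carbonyl and alters the fluorophenyl group together, and the compounds shown do not separate these two parts. On these data alone, how a plain benzoyl group without fluorine, or a longer chain, would read on this nitrogen stays open.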